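Chloro-to-hydrogen step on the anilino ring of compound 1

The source may report more compounds than this note shows. Statements on the series, on what has been measured and on what is new or still open speak of the compounds shown alone.

Measured so far:
compound 1, `CCCCn1cnc2c(Nc3cccc(Cl)c3)nc(NCOCc3ccc(/C=C/C(=O)Nc4ccccc4N)cc3)nc21`: in a functional assay on NCI-H460 cells (Homo sapiens) for antiproliferative activity, read by CCK-8 assay, with a stated time of 72 h, tested at 8 uM (on this read-out lower numbers stand for a weaker effect and higher numbers for a stronger effect at the one concentration tested), compound 1 gives 51.1%
compound 2, `CC(C)n1cnc2c(Nc3cccc(Cl)c3)nc(NCOCc3ccc(/C=C/C(=O)Nc4ccccc4N)cc3)nc21`: in this assay compound 2 gives 61.1%

Compound 1 stands lowest of the two numbers, and its nearest neighbour is compound 2, with a number 10 percentage points higher from compound 1 to compound 2 (within the scatter); the two values are therefore not distinguishable. Compound 3, `CCCCn1cnc2c(Nc3ccccc3)nc(NCOCc3ccc(/C=C/C(=O)Nc4ccccc4N)cc3)nc21`, is not yet measured. Its change from compound 1 is hydrogen in place of chloro on an aromatic carbon, on the aniline ring at the other end of the shared core. Within the data shown here, no measured step concerns this part of the molecule: the single step in hand (a number 10 percentage points higher from compound 1 to compound 2 (within the scatter)) touches the alkyl group on the aromatic nitrogen and was within the scatter, so it gives no direction for a change on the anilino ring. For compound 3 a step of a number 6.1 percentage points lower from compound 1 to compound 3 (within the scatter) is expected, none beyond the scatter. Compound 3 is estimated at 45% in this assay, with a range from 28% to 62%.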

Compound 3, a percentage reported as inhibition, at one concentration (the size of the read-out at that concentration, not a potency): 34.2%
Compound 3: middle estimate off by 10.8 percentage points, on the high side; measured number inside the range.
By their numbers in this assay, from the lowest: compound 3; then compounds 1 and 2 (each within the scatter of the next).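

In this assay, among these compounds, the change from 3-chlorophenyl to phenyl gives a number 16.9 percentage points lower from compound 1 to compound 3 (beyond the scatter), so this is the first step to lie beyond the scatter and the first reading on the anilino end of the molecule. With butyl on the aromatic nitrogen, the chloro on this ring therefore counts towards the effect at the one concentration tested, and hydrogen in its place gives up part of that effect, to a modest extent. Nothing measured on these compounds accounts for the drop.

From the compounds shown here alone, it remains open whether the same step holds with isopropyl on the aromatic nitrogen, as in compound 2. Also open, going by these compounds, is whether fluoro, bromo, methyl or methoxy on the same aromatic carbon would keep the level seen with chloro or fall to that seen with hydrogen.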